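Trifluoromethyl in Place of Methyl on a Shared Core

The compounds below may be only part of what the source reports. "The series", "measured", "known", "first", "only" and "open" are said of these compounds alone.

Compound 1, `COc1ccc(/C=C/c2ccc3ccccc3c2)cc1`, gives > 5000 nM in a functional assay on SK-MEL-28 cells (Homo sapiens) for inhibition (a higher number here means a weaker inhibitor, a lower number a stronger inhibitor), a limit of the assay.
Compound 2, `COc1cccc(/C=C\c2ccc3ccccc3c2)c1`, gives 1920 nM in this assay.
Compound 3, `FC(F)(F)Oc1ccc(/C=C/c2ccc3ccccc3c2)cc1`, gives > 5000 nM in this assay, a limit of the assay.

Within the data shown here, compound 2 is the only compound with a number in this assay; the other two values are limits, as the limit of > 5000 nM in this assay, at which 2 of the 3 values shown sit, records. Compound 1 and compound 2 have the same atoms joined differently, and the difference between the two cores is not broken down here. From compound 1 to compound 3 the change is trifluoromethyl in place of methyl on an oxygen on an aromatic ring, and in this assay it gives a step that the two limits leave unreadable from compound 1 to compound 3. The unmeasured compound 4, `FC(F)(F)Oc1cccc(/C=C\c2ccc3ccccc3c2)c1`, carries the same change from compound 2: trifluoromethyl in place of methyl on an oxygen on an aromatic ring.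

The step from compound 2 to compound 4 is expected to be a 1.3-fold higher number from compound 2 to compound 4 (0.11 log units; within the scatter), a wide guess since a step that the two limits leave unreadable from compound 1 to compound 3 cannot be read. Compound 4 is accordingly estimated at 2500 nM in this assay, between 900 nM and 6000 nM, with a real chance that only a limit is reported.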

Compound 4, half-maximal inhibitory concentration: 3500 nM
Beside the measured number, compound 4's estimate is 1.4-fold (0.15 log units) below it; the measured number falls inside the stated range.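

On the core of compound 2, trifluoromethyl in place of methyl on an oxygen on an aromatic ring gives a 1.8-fold higher number from compound 2 to compound 4 (0.26 log units; within the scatter) in this assay, so methoxy and trifluoromethoxy cannot be told apart on this core. Among these compounds, the same replacement on the core of compound 1 cannot be read, as compound 1 and compound 3 both sit at a limit of the assay, not at a number: the limit of > 5000 nM in this assay, at which 2 of the 4 values shown sit. This leaves a single readable step, which shows how the replacement reads on one core but does not show whether it carries from one core to the other, as there is no second step to set against it.

The compounds shown leave open how this series responds to other groups on the core of compound 2. Whether an amine or a carboxylic acid in place of the methoxy would give a step beyond the scatter from compound 2 remains an open question.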